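Nitro in place of methyl on the shared core

A few compounds are considered here, and "the series" means these few. Any claim that something is new, unique, unknown or untested is made for them only; others in the source may bear on it.

Of the compounds shown here, three that share one core have been measured in an ADME assay on NIH3T3 cells (Mus musculus) for cytotoxicity, read by MTT assay; on this read-out lower numbers stand for stronger inhibition and higher numbers for weaker inhibition. Compound 1 `N#Cc1c(-c2ccc(O)cc2)c(C#N)c(=O)n(/N=C/c2cn(-c3ccccc3)nc2-c2ccccc2)c1N` gives 110 ug/mL. Compound 3 `Cc1ccc(-c2c(C#N)c(N)n(/N=C/c3cn(-c4ccccc4)nc3-c3ccccc3)c(=O)c2C#N)cc1` gives 98 ug/mL, the lowest of the two numbers, though the step of a 1.1-fold lower number from compound 1 to compound 3 (0.05 log units; within the scatter) lies within the scatter. For compound 2 `N#Cc1c(-c2ccc(F)cc2)c(C#N)c(=O)n(/N=C/c2cn(-c3ccccc3)nc2-c2ccccc2)c1N` this assay reports only a limit, > 200 ug/mL. The step of an at least 2.0-fold lower number from compound 2 to compound 3 (0.30 log units; that floor lies within the scatter) therefore has a floor that is itself within the scatter.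

Compound 4 `N#Cc1c(-c2ccc([N+](=O)[O-])cc2)c(C#N)c(=O)n(/N=C/c2cn(-c3ccccc3)nc2-c2ccccc2)c1N` is the one not yet measured; it differs from compound 3 by nitro in place of methyl on an aromatic carbon. Two measured steps end at compound 3 and touch the same aromatic carbon: the step of a 1.1-fold lower number from compound 1 to compound 3 (0.05 log units; within the scatter), which stays within the scatter, and the step of an at least 2.0-fold lower number from compound 2 to compound 3 (0.30 log units; that floor lies within the scatter), whose floor stays within the scatter. For the measured compounds named here, neither step involves a nitro group, and none of the three measured compounds carries one, so the move to nitro has no direct precedent among them. Given that the two measured changes at this carbon produced no step clearly beyond the scatter, no step beyond the scatter is expected in this assay either.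

Compound 4 is thus expected to give 110 ug/mL in this assay, with a range from 55 ug/mL to 220 ug/mL. The step this estimate means is a 1.1-fold higher number from compound 3 to compound 4 (0.05 log units; within the scatter).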

Compound 4, half-maximal inhibitory concentration: 84 ug/mL
Beside the measured number, compound 4's estimate is 1.3-fold (0.12 log units) above it; the range from low to high includes it.
By their numbers in this assay, from the lowest: compounds 4, 3 and 1 (each within the scatter of the next). At a limit, above all of these: compound 2.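

With nitro on this aromatic carbon, the change from 4-methylphenyl to 4-nitrophenyl leaves the read-out in this assay within the scatter, as a 1.2-fold lower number from compound 3 to compound 4 (0.07 log units; within the scatter) and a 1.3-fold lower number from compound 1 to compound 4 (0.12 log units; within the scatter) show, so hydroxy, methyl and nitro now form a set of three groups that this assay does not separate at this position. Fluoro is the one group that goes against this pattern, and the comparison with nitro gives the first step at this carbon that clears the scatter, with an at least 2.3-fold lower number from compound 2 to compound 4 (0.37 log units; beyond the scatter), a modest step at the least. Compound 2 is known only through a limit, so that step is a floor and its full size cannot be read from these compounds: the limit of > 200 ug/mL in this assay, at which 1 of the 4 values shown sits.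

The compounds shown carry no chloro, amine or carboxylic acid at this carbon, so it remains open whether the separate standing of compound 2 belongs to fluoro alone or would be shared by other groups. All four compounds also carry their group at the same place on the ring, which leaves open whether a group moved elsewhere on that ring would behave in the same way in this assay.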